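The source may hold more compounds than are shown below. What is called first, only, known or untested is meant among the compounds shown, and "the series" means these compounds.

Within the data shown here, in an ADME assay on THP-1 cells (Homo sapiens) for cytotoxicity, read by flow cytometry and propidium iodide staining, with a stated time of 72 h (on this read-out higher numbers stand for weaker inhibition and lower numbers for stronger inhibition), only two compounds have numbers so far. Compound 1 `CC(=O)Nc1ccc2oc(-c3ccccc3)cc(=O)c2c1` gives 97000 nM, while compound 2 `CC(=O)Nc1ccc2oc(-c3ccc(F)cc3)cc(=O)c2c1` gives 22000 nM. Compound 2 therefore holds the lower of the two numbers, which on this read-out means the stronger inhibition.

Compound 3 `CC(=O)Nc1ccc2oc(-c3ccc(C(F)(F)F)cc3)cc(=O)c2c1` keeps the core of compound 2 and changes one group: trifluoromethyl in place of fluoro on an aromatic carbon, para to a large group (trifluoromethyl in place of fluoro on an aromatic carbon).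

Among the measured compounds shown here, only one measured step bears on this change. Placing fluoro on that same aromatic carbon, in place of hydrogen, gave a 4.4-fold lower number from compound 1 to compound 2 (0.64 log units; beyond the scatter), a modest step that lies beyond the scatter. For the measured compounds named here, no measured pair goes from fluoro to trifluoromethyl, so this single step is thin evidence, and it gives a direction only loosely. A small further move towards lower numbers in this assay seems the most likely outcome, though a result within the scatter would be no surprise. The expected step is a 1.4-fold lower number from compound 2 to compound 3 (0.14 log units; within the scatter). For compound 3 the estimated value is 16000 nM, with an expected range from 5000 nM to 50000 nM.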

Compound 3, half-maximal inhibitory concentration: 10000 nM
Compound 3: middle estimate off by 1.6-fold (0.20 log units), on the high side; the range from low to high includes it.
By their numbers in this assay, from the lowest: compound 3; then compound 2; then compound 1.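

Replacing fluoro with trifluoromethyl on this aromatic carbon gives a 2.2-fold lower number from compound 2 to compound 3 (0.34 log units; beyond the scatter) in this assay and shows that the number can still fall after the first substitution, which the earlier pair could not show. Going directly from hydrogen to trifluoromethyl at the same carbon gives a 9.7-fold lower number from compound 1 to compound 3 (0.99 log units; beyond the scatter) and places the three compounds in one order, with hydrogen highest, fluoro in the middle and trifluoromethyl lowest; none of the three goes against this order, and compound 3 shows the strongest inhibition among them. No measurement at hand explains why the number falls across these three groups.

The number of heavy atoms and the number of fluorine atoms on this carbon rise together across the three compounds, so these results cannot separate one from the other. A methyl group or a chlorine atom on the same carbon would test whether the order extends to groups without fluorine, while an amine or a carboxylic acid there would test it on groups of a very different kind.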